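Benzamide in place of arylurea on a pyrazole series

The source may report more compounds than this note shows. Statements on the series, on what has been measured and on what is new or still open speak of the compounds shown alone.

Of the compounds shown here, three sharing one core have been measured in a functional assay on SR cells (Homo sapiens) for inhibition, read by sulforhodamine B assay, with a stated time of 48 h; a lower number here means a stronger inhibitor of growth, a higher number a weaker inhibitor of growth. Compound 1 `O=C(Nc1cccc(-n2cc(-c3ccncc3)c(-c3ccc(Cl)c(O)c3)n2)c1)Nc1cccc(C(F)(F)F)c1` gives 20000 nM. Compound 2 `COc1cc(-c2nn(-c3cccc(NC(=O)Nc4ccc(Cl)c(Cl)c4)c3)cc2-c2ccncc2)ccc1Cl` gives 2800 nM, and compound 3 `COc1cc(-c2nn(-c3cccc(NC(=O)Nc4cccc(C(F)(F)F)c4)c3)cc2-c2ccncc2)ccc1Cl` gives 2840 nM. Compound 3 therefore stands second highest of the three numbers: its value and that of compound 2 lie within the scatter of each other, while compound 1 sits well above both, as the step of a 7.0-fold lower number from compound 1 to compound 3 (0.85 log units; beyond the scatter) shows.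

Compound 4 `COc1cc(-c2nn(-c3cccc(NC(=O)c4ccccc4)c3)cc2-c2ccncc2)ccc1Cl` differs from compound 3 by phenyl in place of (3-(trifluoromethyl)phenyl)amino on a carbonyl carbon. Among the measured compounds shown here, only one measured step touches the same region: a 1.0-fold higher number from compound 2 to compound 3 (0.01 log units; within the scatter), which is within the scatter and exchanges one aryl group for another on the amide-type nitrogen. No measured step removes that nitrogen and its aryl group altogether, so nothing among these compounds tells how large the change to compound 4 will be. For the measured compounds named here, on this footing, compound 4 is expected to show a step of a 2.1-fold higher number from compound 3 to compound 4 (0.32 log units; beyond the scatter) in this assay, with a wide range because the move has no direct precedent. The estimated value for compound 4 is 6000 nM, between 1500 nM and 25000 nM.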

Compound 4, concentration for total growth inhibition: > 100000 nM
Compound 4 was reported as a limit (the forecaster's own chance of this, stated with the estimate: 15%); at least 16-fold (1.22 log units) between middle value and limit.
By their numbers in this assay, from the lowest: compounds 2 and 3 (each within the scatter of the next); then compound 1. At a limit, above all of these: compound 4.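

In this assay compound 4 is reported only as a limit, not as a number: the limit of > 100000 nM in this assay, at which 1 of the 4 values shown sits.

Setting phenyl in place of (3-(trifluoromethyl)phenyl)amino on the carbonyl carbon gives an at least 35-fold higher number from compound 3 to compound 4 (1.54 log units; beyond the scatter) and setting it in place of (3,4-dichlorophenyl)amino gives an at least 35-fold higher number from compound 2 to compound 4 (1.55 log units; beyond the scatter) while exchanging one aryl group for the other on the amide-type nitrogen gave only a 1.0-fold higher number from compound 2 to compound 3 (0.01 log units; within the scatter). In these pairs, the series keeps its reading through a change of aryl group on that nitrogen but not through the change from arylurea to benzamide.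

The compounds shown leave open whether the large step belongs to the loss of the amide-type nitrogen or to the loss of the ring substituents. A plain phenylamino group on the carbonyl carbon, or a benzamide carrying trifluoromethyl on its phenyl ring, would separate the two.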